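This account rests on a few compounds, and the source may have more. Where it says the series, first, only, none or still open, it means among the compounds named here.

Working notes on the series. Compound 1 `COc1ccc(OC)c(/C=C/C(=O)/C=C/c2cc3ccccc3nc2Oc2ccc(Br)cc2)c1` and compound 2 `COc1ccc(/C=C/C(=O)/C=C/c2cc3ccccc3nc2Oc2cccc(Cl)c2)c(OC)c1` share one core and differ on both ends of it. In a functional assay on NCI-H460 cells (Homo sapiens) for cytotoxicity, read by MTT assay, with a stated time of 48 h (a higher number here means a weaker inhibitor, a lower number a stronger inhibitor), compound 1, which carries 2,5-dimethoxyphenyl, gives > 10000 nM as a limit of the assay and not a number. Compound 2 gives > 10000 nM, also a limit of the assay, so its position is known only as a limit.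

Compound 3 `COc1ccc(OC)c(/C=C/C(=O)/C=C/c2cc3ccccc3nc2Oc2cccc(Cl)c2)c1` keeps the rest of compound 2 and has 2,5-dimethoxyphenyl in place of 2,4-dimethoxyphenyl on a double-bonded chain carbon bound to a double-bonded chain carbon. Going by the values given here, no measured step isolates this change. Compound 2 sits with compound 1 at the limit of > 10000 nM in this assay, at which 2 of the 2 values shown sit, so no step beyond the scatter is expected in this assay, in either direction, and a further reading as a limit is the likeliest result.

The expected size of the change, a step that the limit leaves unreadable from compound 2 to compound 3, is an estimate and stays within the scatter. For compound 3 the estimated value is 12000 nM, with an expected range from 5000 nM to 30000 nM.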

Compound 3, half-maximal inhibitory concentration: > 10000 nM
Compound 3 gave a limit, no number (the forecaster's own chance of this, stated with the estimate: 85%); the middle value is on the limit's open side.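

The steps from compound 2 to compound 3 and from compound 1 to compound 3 cannot be read in this assay, because all three compounds give a limit and not a number: the limit of > 10000 nM in this assay, at which 3 of the 3 values shown sit.

The compounds shown leave open whether any change at either end of the shared core would give a numerical value in this assay.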